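The compounds below may be only part of what the source reports. "The series", "measured", "known", "first", "only" and "open" are said of these compounds alone.

Three compounds have so far been measured in a toxicity assay on MCF-10A cells (Homo sapiens) for cytotoxicity, read by MTT assay, with a stated time of 48 h; a higher number here means a weaker inhibitor, a lower number a stronger inhibitor:

Compound 1 `O=C(/C=C/c1ccc2c(c1)B(O)OC2)c1cccs1` gives 13800 nM.
Compound 2 `CCOC(=O)c1ccc(C(=O)/C=C/c2ccc3c(c2)B(O)OC3)cc1` gives 12900 nM.
Compound 3 `O=C(/C=C/c1ccc2c(c1)B(O)OC2)c1ccc(O)c(O)c1` gives > 100000 nM.

Compound 1 holds the higher of the two plain numbers, but compound 2 sits so close that the gap lies within the usual scatter. Compound 3 is reported only as a limit of the assay, (the limit of > 100000 nM in this assay, at which 1 of the 3 values shown sits), not as a number. Compound 4 `Nc1cccc(C(=O)/C=C/c2ccc3c(c2)B(O)OC3)c1` has not yet been measured; it differs from compound 1 by 3-aminophenyl in place of thiophen-2-yl on a carbonyl carbon. Among the compounds with values here, no measured pair isolates this change, so no step can be read from the data. The step in this assay is expected to be small, at most at the edge of the scatter, with no clear direction. Compound 4 is therefore estimated at 20000 nM, with a range from 7000 nM to 60000 nM. This estimate amounts to an expected step of a 1.4-fold higher number from compound 1 to compound 4 (0.16 log units; within the scatter).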

Compound 4, half-maximal inhibitory concentration: 19600 nM
Beside the measured number, compound 4's estimate is 1.0-fold (0.01 log units) above it; the measured number falls inside the stated range.
By their numbers in this assay, from the lowest: compounds 2, 1 and 4 (each within the scatter of the next). At a limit, above all of these: compound 3.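

In this assay, within the data shown here, 3-aminophenyl in place of thiophen-2-yl on a carbonyl carbon gives a 1.4-fold higher number from compound 1 to compound 4 (0.15 log units; within the scatter), the first step that can be read at this place. The exchange of the five-membered ring for a six-membered one carrying an amine therefore leaves the number within the scatter. No measured property shown accounts for this result. From the compounds shown here alone, it remains open what an unsubstituted phenyl would give at this place in this assay, and so whether the amine contributes at all. A carboxylic acid in place of the amine also remains untested among the compounds shown.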